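The compounds below may be only part of what the source reports. "The series", "measured", "known", "first", "only" and "open" are said of these compounds alone.

Measured so far in a functional assay on ACHN cells (Homo sapiens) for inhibition, read by sulforhodamine B assay, with a stated time of 48 h; on this read-out lower numbers stand for stronger inhibition of growth and higher numbers for weaker inhibition of growth:
- compound 1 `CCCCCCCCCCCC[C@@H](O)[C@H]1CC[C@H]([C@H](O)CCCCCCCCCCNC(=O)c2ccnn2C)O1` gives 24000 nM
- compound 2 `CCCCCCCCCCCC[C@@H](O)[C@H]1CC[C@H]([C@H](O)CCCCCCCCCCN(C)C(=O)c2ccnn2C)O1` gives 11000 nM

Compound 2 at 11000 nM holds the lower of the two numbers, so it shows the stronger inhibition of growth so far. Within the data shown here, its only neighbour is compound 1.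

The next structure is compound 3 `CCCCCCCCCCCC[C@@H](O)[C@H]1CC[C@H]([C@H](O)CCCCCCCCCCNCc2ccnn2C)O1`. The change is ((1-methyl-1H-pyrazol-5-yl)methyl)amino in place of methyl((1-methyl-1H-pyrazol-5-yl)carbonyl)amino on a saturated chain carbon, ten or more bonds along the chain from an oxygen on a saturated carbon and a saturated ring carbon. The carbonyl goes and the nitrogen carries hydrogen in place of methyl, as in compound 1.

Among the measured compounds shown here, one measured step bears on this nitrogen: a 2.2-fold lower number from compound 1 to compound 2 (0.34 log units; beyond the scatter), a modest change. For the measured compounds named here, no measured pair shows the loss of the carbonyl, so that part of the change has no measured size, and the evidence is thin. A step no larger than that modest one is expected in this assay with a slight lean toward a lower number. The expected step is a 1.4-fold lower number from compound 2 to compound 3 (0.14 log units; within the scatter) and it may not clear the scatter. For compound 3 the estimate is 8000 nM with an expected range of 2500 nM to 25000 nM.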

Compound 3, concentration for 50% growth inhibition: 3090 nM
The estimate for compound 3 lay 2.6-fold (0.41 log units) above the measured number; the range from low to high includes it.
By their numbers in this assay, from the lowest: compound 3; then compound 2; then compound 1.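

In this assay, the step of a 7.8-fold lower number from compound 1 to compound 3 (0.89 log units; beyond the scatter) gives the first measured size for losing the carbonyl at this position, with hydrogen kept on the nitrogen. The step of a 3.6-fold lower number from compound 2 to compound 3 (0.55 log units; beyond the scatter) places the amine of compound 3 ahead of the methylated amide as well, so among these three compounds, exchanging the carbonyl for a methylene link lowers the number further than methylating the amide nitrogen does, and compound 3 shows the strongest inhibition of growth. Nothing measured here speaks to what lies behind these steps.

Still open, from the compounds shown here alone, is whether a methyl on the amine nitrogen of compound 3 would shift the number as it did on the amide nitrogen, or whether a 2-hydroxyethyl group there would be tolerated. Also open, going by these compounds, is how much of the amine result depends on the (1-methyl-1H-pyrazol-5-yl)methyl group itself, which a benzyl group or a simple dimethylamino group at the end of the same chain would test, and whether the order of amine and amide holds on a shorter chain.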